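Adding a Second Chloro to a Purine-Based Cytotoxic Agent

The source may hold more compounds than are shown below. What is called first, only, known or untested is meant among the compounds shown, and "the series" means these compounds.

Measured so far:
Compound 1 `ClCc1ccccc1Cn1cnc2c(Cl)ncnc21`: 10700 nM
Compound 2 `ClCc1cccc(Cn2cnc3ncnc(Cl)c32)c1`: 1940 nM
Compound 3 `ClCc1cccc(Cn2cnc3c(Cl)nc(Cl)nc32)c1`: 1860 nM

These three compounds were tested in a functional assay on UACC-257 cells (Homo sapiens) for cytotoxicity, read by sulforhodamine B assay, with a stated time of 48 h; a higher number here means a weaker inhibitor of growth, a lower number a stronger inhibitor of growth. Compound 1 gives 10700 nM, compound 2 gives 1940 nM and compound 3 gives 1860 nM. Among these numbers, compound 2 stands second highest. Its nearest neighbour is compound 3, whose number is within the usual scatter of the measurement, so the two cannot be told apart. Compound 1 lies furthest away, with a higher number that is beyond the scatter, meaning compound 1 is the weaker inhibitor of growth in this group.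

The next compound to be measured is compound 4 `ClCc1cccc(Cn2cnc3nc(Cl)nc(Cl)c32)c1`. Compared with compound 2, the change is chloro in place of hydrogen on an aromatic carbon. Within the data shown here, no pair of measured compounds differs by exactly this change, so there is no measured step to lean on. Compound 3 also carries two chloro groups on its core and sits within the scatter of compound 2, which suggests that adding a chloro here need not move the number much.

For compound 4 in this assay the expected value is 1500 nM, with a range from 600 nM to 4000 nM. The expected step from compound 2 to compound 4 is therefore a 1.3-fold lower number from compound 2 to compound 4 (0.11 log units; within the scatter), a change estimated to stay within or only just beyond the scatter.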

Compound 4, concentration for 50% growth inhibition: 3460 nM
Beside the measured number, compound 4's estimate is 2.3-fold (0.36 log units) below it; measured number inside the range.
By their numbers in this assay, from the lowest: compounds 3, 2 and 4 (each within the scatter of the next); then compound 1.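

In this assay, among these compounds, putting chloro in place of hydrogen on the aromatic carbon between two ring nitrogen atoms gives a 1.8-fold higher number from compound 2 to compound 4 (0.25 log units; within the scatter) and this is the first direct reading of this change. The two compounds cannot be told apart, so this position can carry a chloro group without a measurable shift in growth inhibition, and compound 4 keeps a number in the same range as compound 2. This rests on a single pair in a single cell line, and nothing measured here bears on why the number holds.

On these data alone, it remains open whether a different group on this same carbon, such as an amine or a methoxy group, would leave the number just as close to that of compound 2, or would move it beyond the scatter. As far as these compounds go, it is also open whether the same swap of hydrogen for chloro would read the same way with the chloromethyl group placed as it is in compound 1.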